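Aryl swap on the cinnamate ester series: compound 3 to 4

The source may hold more compounds than are shown below. What is called first, only, known or untested is meant among the compounds shown, and "the series" means these compounds.

Values in a functional assay on the whole organism (strain Kunming) with Mus musculus as the target, with a stated time of 0.5 h; on this read-out lower numbers stand for an effect already at smaller amounts and higher numbers for an effect only at larger amounts of compound:
- compound 1 `COc1ccccc1/C=C/C(=O)OC/C=C/c1cc(OC)c(OC)cc1OC`: 780 umol/kg
- compound 2 `COc1cc(OC)c(OC)cc1/C=C/COC(=O)/C=C/c1c(OC)ccc(OC)c1OC`: > 674 umol/kg. This value is a limit of the assay.
- compound 3 `COc1cc(OC)c(OC)cc1/C=C/COC(=O)/C=C/c1cccc(Br)c1`: 497 umol/kg

Only two of the three entries are numbers. Compound 3, at 497 umol/kg, lies within the scatter of compound 1, at 780 umol/kg, so neither can be ranked over the other.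

The next change leads to compound 4 `COc1cc(OC)c(OC)cc1/C=C/COC(=O)/C=C/c1ccc(Cl)cc1`, with 4-chlorophenyl in place of 3-bromophenyl on a double-bonded chain carbon bound to a double-bonded chain carbon.

For the measured compounds named here, one measured step bears on this place: a 1.6-fold lower number from compound 1 to compound 3 (0.20 log units; within the scatter). Going by the values given here, it stayed within the scatter, and it is the only guide, since it involves a different pair of groups. No step beyond the scatter is therefore expected in this assay, and no direction can be assigned.

The expected change is a 1.0-fold higher number from compound 3 to compound 4 (0.02 log units; within the scatter). Compound 4 is estimated at 520 umol/kg, with an expected range of 260 umol/kg to 1000 umol/kg.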

Compound 4, dose for half-maximal effect: > 514 umol/kg
Compound 4 ended at the assay's limit (the forecaster's own chance of this, stated with the estimate: 15%); the middle value lies beyond the limit too.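

In this assay compound 4 gives a limit of the assay and not a number: the limit of > 514 umol/kg in this assay, at which 1 of the 4 values shown sits. For the compounds shown here, for 4-chlorophenyl in place of 3-bromophenyl on a double-bonded chain carbon bound to a double-bonded chain carbon, the only reading is an at least 1.0-fold higher number from compound 3 to compound 4 (0.01 log units; that floor lies within the scatter), so this change does not rank the two compounds, and the step from compound 1 to compound 4 cannot be read. Compound 2 also gives a limit and not a number, so two of the entries in this series now carry no number: the limit of > 674 umol/kg in this assay, at which 1 of the 4 values shown sits.

Going by these compounds alone, no step at this place has yet been read beyond the scatter, so it remains open whether the value responds to this position at all. Also open, from the compounds shown here alone, is how an amine or a carboxylic acid in place of the 4-chlorophenyl would read.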